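Does a longer chain move compound 2 off its limit?

The source may hold more compounds than are shown below. What is called first, only, known or untested is meant among the compounds shown, and "the series" means these compounds.

Measured so far:
Compound 1 `CC(C)CSc1nc(N)nc2c1ncn2/C=C1/CC1(CO)CO`: > 20000 nM
Compound 2 `C=CCOc1nc(N)nc2c1ncn2/C=C1/CC1(CO)CO`: > 20000 nM
Compound 3 `CCOc1nc(N)nc2c1ncn2/C=C1/CC1(CO)CO`: > 20000 nM

In an ADME assay on Akata cells (Homo sapiens) for cytotoxicity, with a stated time of 7 days (on this read-out higher numbers stand for lower toxicity in this test and lower numbers for higher toxicity in this test), compound 2 gives > 20000 nM, which is a limit and not a number. The other two values are limits as well, and the overall picture is the limit of > 20000 nM in this assay, at which 3 of the 3 values shown sit. Compound 4 `CCCCCCCCOc1nc(N)nc2c1ncn2/C=C1/CC1(CO)CO` differs from compound 2 in one place: heptyl in place of vinyl on a saturated chain carbon bound to an oxygen on an aromatic ring. Put simply, allyloxy gives way to octyloxy. Going by the values given here, three measured steps bear on this change: a step that the two limits leave unreadable from compound 2 to compound 3, a step that the two limits leave unreadable from compound 1 to compound 2 and a step that the two limits leave unreadable from compound 1 to compound 3. None has a readable size, so together they show no measured trend. Octyloxy is also a longer chain than any group on the measured compounds. The most likely result is therefore another limit, with some chance of a number lower down, which would mean higher toxicity. The expected change is a number no higher from compound 2 to compound 4 (the limit leaves the size open). For compound 4 the estimate is 20000 nM, with an expected range of 7000 nM to 40000 nM.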

Compound 4, half-maximal cytotoxic concentration: > 20000 nM
Compound 4: only a limit was reported (the forecaster's own chance of this, stated with the estimate: 65%); the middle value lies on the limit itself.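

Compound 4 also gives a limit and not a number, so the steps to it from compound 1, compound 2 and compound 3 cannot be read. The compounds shown leave open how far these groups differ, if at all, in this assay.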